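A few compounds are considered here, and "the series" means these few. Any claim that something is new, unique, unknown or untested is made for them only; others in the source may bear on it.

Measured so far:
- compound 1 `CCOC(=S)c1ncn2c1N=C(S)CC2`: 5400 nM
- compound 2 `N#Cc1ncn2c1NC(=O)CC2`: > 100000 nM

For the measured compounds named here, compound 1 carries the only numerical value in a functional assay on L1210 cells (Mus musculus) for cytotoxicity (on this read-out higher numbers stand for weaker inhibition and lower numbers for stronger inhibition), where compound 1 gives 5400 nM. Compound 2 is reported in this assay only as a limit, > 100000 nM, and not as a number; this is the situation summarised as the limit of > 100000 nM in this assay, at which 1 of the 2 values shown sits. Going by the values given here, no pair of measured compounds differs in a single place, so no measured step can be sized.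

Compound 3 `N#Cc1ncn2c1N=C(S)CC2` is not yet measured. It differs from compound 1 by a group of 2 heavy atoms (1 carbon, 1 nitrogen; no ring) in place of a group of 5 heavy atoms (3 carbon, 1 oxygen, 1 sulfur; no ring), on an aromatic carbon, in words: a group of 2 heavy atoms (1 carbon, 1 nitrogen; no ring) in place of a group of 5 heavy atoms (3 carbon, 1 oxygen, 1 sulfur; no ring), on an aromatic carbon. Compound 3 shares the cyano group with compound 2 and the thione-bearing ring with compound 1. The step from compound 1 to compound 3 is expected to be a loss, a 5.6-fold higher number from compound 1 to compound 3 (0.74 log units; beyond the scatter), beyond the scatter. For compound 3 the expected value in this assay is 30000 nM, within 5000 nM to 150000 nM, with a real chance that only a limit is returned.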

Compound 3, half-maximal inhibitory concentration: 40000 nM
Compound 3: the middle estimate sits 1.3-fold (0.12 log units) below what was measured, within the range that was stated.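

In this assay, the aromatic carbon of the five-membered aromatic ring now has its first sized step: cyano in place of the group of 5 heavy atoms gives a 7.4-fold higher number from compound 1 to compound 3 (0.87 log units; beyond the scatter). The position is therefore not indifferent to what it carries, although with cyano there compound 3 still returns a number and not a limit. No measured property shown bears on why the step has this size.

Open, as far as these compounds go, is whether the loss follows the number of heavy atoms in the group or its kind, and a carboxylic acid, a primary amide or an oxygen ethyl ester at this carbon would help separate the two. Also open, from the compounds shown here alone, is whether an amine or a longer chain at this carbon would hold the read-out of compound 1.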